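The compounds below may be only part of what the source reports. "The series", "measured", "known", "first", "only" and "open" are said of these compounds alone.

Two compounds of one series, built on a shared core, have been tested in an ADME assay on L02 cells (Homo sapiens) for cytotoxicity, read by MTT assay; a lower number here means a stronger inhibitor, a higher number a weaker inhibitor. Compound 1 `COc1cc(/C=C/c2nc(Nc3ccc(C(F)(F)F)cc3)c3sccc3n2)cc(OC)c1OC` gives 436000 nM in this assay. Compound 2 `COc1cc(/C=C/c2nc(NCc3ccc(Cl)cc3)c3sccc3n2)cc(OC)c1OC` gives 4320000 nM in this assay, the higher of the two numbers: the step of a 9.9-fold higher number from compound 1 to compound 2 (1.00 log units; beyond the scatter) follows from exchanging the group on the nitrogen on the aromatic ring.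

Compound 3 `COc1cc(/C=C/c2nc(NCc3ccncc3)c3sccc3n2)cc(OC)c1OC` is not yet measured. It differs from compound 2 in one place: pyridin-4-yl in place of 4-chlorophenyl on a saturated chain carbon bound to a nitrogen on an aromatic ring. Among the measured compounds shown here, no measured step concerns this exchange; the only step available, a 9.9-fold higher number from compound 1 to compound 2 (1.00 log units; beyond the scatter), changed a different part of the substituent and alters the ring alongside the linker, so it does not bear directly on the present change. With nothing in the data pointing either way, the step is expected to be small, a 1.2-fold higher number from compound 2 to compound 3 (0.06 log units; within the scatter), with no change beyond the scatter. Compound 3 is therefore estimated at 5000000 nM in this assay, within a range from 1500000 nM to 20000000 nM.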

Compound 3, half-maximal inhibitory concentration: 374000 nM
The estimate for compound 3 lay 13-fold (1.13 log units) above the measured number; the measured number lies below the stated range.
By their numbers in this assay, from the lowest: compounds 3 and 1 (each within the scatter of the next); then compound 2.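

At this position, on a saturated chain carbon bound to a nitrogen on an aromatic ring, the ring carried by the chain decides much of the number in this assay: pyridin-4-yl in place of 4-chlorophenyl gives a 12-fold lower number from compound 2 to compound 3 (1.06 log units; beyond the scatter) and thus a step beyond the scatter. The chain carbon alone therefore does not set the high number of compound 2, since (pyridin-4-yl)methyl in place of 4-(trifluoromethyl)phenyl gives a 1.2-fold lower number from compound 1 to compound 3 (0.07 log units; within the scatter) and leaves the two compounds level. Nothing available accounts for the size of this exchange.

On these data alone, it remains open whether pyridin-3-yl or pyridin-2-yl on the same chain carbon would match pyridin-4-yl. A longer chain, or a 4-chlorophenyl or pyridin-4-yl group set directly on the nitrogen, would show how far the ring and the chain act separately.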